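Notes on replacing the 3,4,5-trimethoxyphenyl group of compound 2

The source may hold more compounds than are shown below. What is called first, only, known or untested is meant among the compounds shown, and "the series" means these compounds.

Measured so far in a functional assay on A549 cells (Homo sapiens) for cytotoxicity, read by MTT assay, with a stated time of 72 h; a higher number here means a weaker inhibitor, a lower number a stronger inhibitor:
- compound 1 `O=C(N/N=C/c1ccc(F)cc1Cl)Nc1cc2c(Nc3ccc(F)c(Cl)c3)ncnc2cc1O[C@H]1CCOC1`: 27200 nM
- compound 2 `COc1cc(/C=N/NC(=O)Nc2cc3c(Nc4ccc(F)c(Cl)c4)ncnc3cc2O[C@H]2CCOC2)cc(OC)c1OC`: 26400 nM

Within the data shown here, compound 2 stands at 26400 nM, level with the only other measured compound. The next compound is compound 3 `O=C(N/N=C/c1ccc(O)cc1)Nc1cc2c(Nc3ccc(F)c(Cl)c3)ncnc2cc1O[C@H]1CCOC1`, in which 4-hydroxyphenyl takes the place of 3,4,5-trimethoxyphenyl on a carbon with a double bond to nitrogen: 4-hydroxyphenyl in place of 3,4,5-trimethoxyphenyl on a carbon with a double bond to nitrogen.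

Among the measured compounds shown here, one measured step bears on this change, as it is an exchange at the same place: 3,4,5-trimethoxyphenyl in place of 2-chloro-4-fluorophenyl gave a 1.0-fold lower number from compound 1 to compound 2 (0.01 log units; within the scatter). Resting on that step, no shift beyond the scatter is expected in this assay. For the measured compounds named here, no measured compound carries 4-hydroxyphenyl, and a single step is thin evidence, so the expected range is kept wide on both sides. The expected step is a 1.1-fold lower number from compound 2 to compound 3 (0.02 log units; within the scatter). For compound 3 the estimated value is 25000 nM, with an expected range of 10000 nM to 60000 nM.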

Compound 3, half-maximal inhibitory concentration: 1320 nM
Compound 3: middle estimate off by 19-fold (1.28 log units), on the high side; measured number below the stated range.
By their numbers in this assay, from the lowest: compound 3; then compounds 2 and 1 (each within the scatter of the next).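

In this assay, 4-hydroxyphenyl in place of 3,4,5-trimethoxyphenyl gives a 20-fold lower number from compound 2 to compound 3 (1.30 log units; beyond the scatter), and 4-hydroxyphenyl in place of 2-chloro-4-fluorophenyl gives a 21-fold lower number from compound 1 to compound 3 (1.31 log units; beyond the scatter) on the same carbon with a double bond to nitrogen. This position therefore responds to the group it carries, which compound 1 and compound 2 did not show, as the exchange between their two substituted phenyl groups stayed within the scatter. Compared with 3,4,5-trimethoxyphenyl, the entering group has fewer heavy atoms and one hydrogen-bond donor in place of none, but compound 3 alone carries it, so these differences cannot be told apart.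

The compounds shown leave open whether the hydroxyl group itself goes with the lower number, or whether an unsubstituted phenyl would stand level with compound 3. A 4-methoxyphenyl or 4-aminophenyl group at this position would separate those readings, and a carboxylic acid on the phenyl ring would test how far the change can be taken. Nothing measured here accounts for the size of these steps.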